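This account rests on a few compounds, and the source may have more. Where it says the series, first, only, none or still open, it means among the compounds named here.

Compound 1 `NCCNc1cc(N2CCCc3ccccc3C2)nc2ccc(F)cc12`: in an ADME assay on HEp-2 cells (Homo sapiens) for cytotoxicity, read by CCK-8 assay, with a stated time of 5 days (on this read-out lower numbers stand for higher toxicity in this test and higher numbers for lower toxicity in this test), compound 1 gives 8000 nM.
Compound 2 `Cc1ccc2nc(N3CCCc4ccc(F)cc4C3)cc(NCCN)c2c1`: in this assay compound 2 reaches only the assay limit, > 3200 nM.
Compound 3 `Cc1ccc2nc(N3CCCc4ccc(F)cc4C3)cc(NC(C)(C)CN)c2c1`: in this assay compound 3 gives 25000 nM.

Compound 3 has the highest of the two numbers shown; its nearest neighbour is compound 1, whose lower number lies beyond the scatter. For the measured compounds named here, the only step measured, a step that the limit leaves unreadable from compound 2 to compound 3, has no readable size because of the limit of > 3200 nM in this assay, at which 1 of the 3 values shown sits. Compound 4 `Cc1ccc2nc(N3CCCc4ccc(F)cc4C3)cc(NCC3CCCCN3)c2c1` differs from compound 3 by (piperidin-2-yl)methyl in place of 1-(aminomethyl)-1-methylethyl on a nitrogen on an aromatic ring. Going by the values given here, no measured step covers this change, and the single recorded step gives no size to lean on, so for compound 4 no step beyond the scatter is expected: a 1.3-fold lower number from compound 3 to compound 4 (0.10 log units; within the scatter). For compound 4 the estimate is therefore 20000 nM, with a range from 6000 nM to 60000 nM.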

Compound 4, half-maximal cytotoxic concentration: 23000 nM
Compound 4: the middle estimate sits 1.2-fold (0.06 log units) below what was measured; the measured number falls inside the stated range.
By their numbers in this assay, from the lowest: compound 1; then compounds 4 and 3 (each within the scatter of the next).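

In this assay, (piperidin-2-yl)methyl in place of 1-(aminomethyl)-1-methylethyl on the nitrogen gives a 1.1-fold lower number from compound 3 to compound 4 (0.04 log units; within the scatter). For the compounds shown here, this is the first readable step at this position, and it shows that a six-membered non-aromatic ring can enter the side group without a change beyond the scatter. The step to compound 4 from compound 2, whose value is a limit, cannot be read: the limit of > 3200 nM in this assay, at which 1 of the 4 values shown sits.

As far as these compounds go, whether the read-out would hold with a side group ending in a hydroxyl or a carboxylic acid instead of an amine stays open. The same goes for a longer chain between the ring-bound nitrogen and the amine.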